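Methyl to Isopropyl on a Ring Nitrogen: Cytotoxicity Outlook

The source may report more compounds than this note shows. Statements on the series, on what has been measured and on what is new or still open speak of the compounds shown alone.

Measured so far:
Compound 1 `C=CC(=O)Nc1cc(Nc2ncc3ncn(-c4ccc(C(C)C)cc4)c3n2)c(OC)cc1N(C)CCN(C)C` — 15300 nM
Compound 2 `C=CC(=O)Nc1cc(Nc2ncc3nc(Nc4ccccc4)n(C)c3n2)c(OC)cc1N(C)CCN(C)C` — 8700 nM

In an ADME assay on HT-29 cells (Homo sapiens) for cytotoxicity, read by MTT assay, with a stated time of 72 h (a lower number here means a stronger inhibitor, a higher number a weaker inhibitor), compound 2 gives 8700 nM, the lowest of the two numbers; compound 1 gives 15300 nM, and the two are within the scatter of each other, so no order can be read from them. Compound 3 `C=CC(=O)Nc1cc(Nc2ncc3nc(Nc4ccccc4)n(C(C)C)c3n2)c(OC)cc1N(C)CCN(C)C` has not yet been measured. It differs from compound 2 by isopropyl in place of methyl on an aromatic nitrogen. For the measured compounds named here, no measured pair shows this change, so only a modest step, if any, is expected from compound 2 to compound 3, with no direction beyond the scatter. For compound 3 the estimate in this assay is 9000 nM, within 4000 nM to 25000 nM, a step of a 1.0-fold higher number from compound 2 to compound 3 (0.01 log units; within the scatter).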

Compound 3, half-maximal inhibitory concentration: 4720 nM
Compound 3: the middle estimate sits 1.9-fold (0.28 log units) above what was measured; low and high end bracket the measured number.
By their numbers in this assay, from the lowest: compounds 3, 2 and 1 (each within the scatter of the next, the first and the last beyond it).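

For the compounds shown here, compound 2 and compound 3 form the first pair here that differs in one place only, so the group on this aromatic nitrogen can now be looked at on its own. In this assay, isopropyl in place of methyl gives a 1.8-fold lower number from compound 2 to compound 3 (0.27 log units; within the scatter), so this exchange produces no readable change at this position. Nothing available explains this result. Still open, from the compounds shown here alone, is whether a longer chain, such as butyl, or a chain ending in an amine on this nitrogen would shift the number beyond the scatter.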